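Restoring a Carboxy Group on the Amide Side Chain

The compounds below may be only part of what the source reports. "The series", "measured", "known", "first", "only" and "open" are said of these compounds alone.

Measured so far in an in vitro assay on BHK cells for inhibition of Glucagon receptor (Homo sapiens); on this read-out higher numbers stand for weaker inhibition and lower numbers for stronger inhibition:
- Compound 1, `COCCCNC(=O)c1ccc(CN(C(=O)Nc2ccc(OC(F)(F)F)cc2)C2CCC(C(C)(C)C)CC2)cc1`: a limit, > 10000 nM
- Compound 2, `CC(C)(C)C1CCC(N(Cc2ccc(C(=O)N3CCCC(C(=O)O)C3)cc2)C(=O)Nc2ccc(OC(F)(F)F)cc2)CC1`: 1000 nM
- Compound 3, `CC(C)(C)C1CCC(N(Cc2ccc(C(=O)NCCC(N)=O)cc2)C(=O)Nc2ccc(OC(F)(F)F)cc2)CC1`: a limit, > 10000 nM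

Compound 3 stands at the weak end of the shown values. Its result is a limit of this assay, not a number, and the limit of > 10000 nM in this assay, at which 2 of the 3 values shown sit, shows that compound 1 shares that limit. Compound 4, `CC(C)(CC(=O)O)NC(=O)c1ccc(CN(C(=O)Nc2ccc(OC(F)(F)F)cc2)C2CCC(C(C)(C)C)CC2)cc1`, differs from compound 3 by 1-(carboxymethyl)-1-methylethyl in place of 2-carbamoylethyl on an amide-type nitrogen.

Within the data shown here, two measured steps bear on this change. Going an at least 10-fold higher number from compound 2 to compound 3 (1.00 log units; beyond the scatter), the 3-carboxypiperidin-1-yl group was swapped for a chain without a carboxy group, and inhibition weakened to the limit. Going an at least 10-fold lower number from compound 1 to compound 2 (1.00 log units; beyond the scatter), introducing the carboxy-bearing ring strengthened inhibition clearly. Compound 4 brings a carboxy group back, now on the 1-(carboxymethyl)-1-methylethyl chain rather than on a ring, so a step toward stronger inhibition is expected, though its size is uncertain because the start is a limit. The expected step is an at least 3.3-fold lower number from compound 3 to compound 4 (0.52 log units; beyond the scatter), and compound 4 is estimated at 3000 nM, in the range 800 nM to 15000 nM.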

Compound 4, half-maximal inhibitory concentration: > 10000 nM
Compound 4 was reported as a limit (the forecaster's own chance of this, stated with the estimate: 35%); middle value at least 3.3-fold (0.52 log units) from the limit.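

Compound 4 carries a carboxy group and is still a limit in this assay, so a carboxy group on the chain at this amide-type nitrogen is not enough by itself to give a measurable value: the limit of > 10000 nM in this assay, at which 3 of the 4 values shown sit. Among these compounds, the one readable step is an at least 10-fold higher number from compound 2 to compound 4 (1.00 log units; beyond the scatter), so a carboxy group on the 1-(carboxymethyl)-1-methylethyl chain does not match the result of the 3-carboxypiperidin-1-yl group. The steps to compound 4 from compound 1 and from compound 3 cannot be read, as each joins two limits.

As far as these compounds go, it remains open whether an unbranched 2-carboxyethyl chain would give a measurable value where the branched chain does not. Also open, from the compounds shown here alone, is whether the ring or its carboxy group matters more in compound 2, a question that a piperidine ring bearing a carbamoyl group could address.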